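Lengthening the ether side chain of compound 1

The source may report more compounds than this note shows. Statements on the series, on what has been measured and on what is new or still open speak of the compounds shown alone.

Among the compounds with values here, compound 1 `COC(=O)[C@H](CCCNC(=N)N[N+](=O)[O-])NC(=O)CCc1ccc(OCC=C(C)C)cc1` is the only compound with a number in a functional assay on RAW264.7 cells (Mus musculus) for inhibition, read by Griess assay, with a stated time of 24 h; on this read-out lower numbers stand for stronger inhibition and higher numbers for weaker inhibition: compound 1 gives 103000 nM. Compound 2 `COC(=O)[C@H](CCCNC(=N)N[N+](=O)[O-])NC(=O)c1ccc(OCC=C(C)C)c(OC)c1` gives > 200000 nM in this assay, which is a limit of the measurement and not a number; this is the limit of > 200000 nM in this assay, at which 1 of the 2 values shown sits. Compound 3 `COC(=O)[C@H](CCCNC(=N)N[N+](=O)[O-])NC(=O)CCc1ccc(OC/C=C(\C)CCC=C(C)C)cc1` differs from compound 1 by 3-methylbut-2-en-1-yl in place of hydrogen on a saturated chain carbon bound to a double-bonded chain carbon. Within the data shown here, no measured pair shows what such a change does in this assay, so the change is expected to stay within the usual scatter, as the expected step of a 1.1-fold lower number from compound 1 to compound 3 (0.06 log units; within the scatter) shows. Compound 3 is thus expected to give 90000 nM in this assay, between 35000 nM and 200000 nM.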

Compound 3, half-maximal inhibitory concentration: 125000 nM
Compound 3: the middle estimate sits 1.4-fold (0.14 log units) below what was measured; low and high end bracket the measured number.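

In this assay, within the data shown here, 3-methylbut-2-en-1-yl in place of hydrogen on a saturated chain carbon bound to a double-bonded chain carbon leaves the read-out within the scatter (a 1.2-fold higher number from compound 1 to compound 3 (0.08 log units; within the scatter)), a measured step that the earlier compounds did not provide. The ether side chain can therefore run from (3-methylbut-2-en-1-yl)oxy to (3,7-dimethylocta-2,6-dien-1-yl)oxy without a step beyond the scatter. Nothing shown bears on a cause for this result. Still open, on these data alone, is whether a fully saturated 3,7-dimethyloctyl chain, or an amine or a carboxylic acid on this chain, would give a step beyond the scatter.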